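The source may report more compounds than this note shows. Statements on the series, on what has been measured and on what is new or still open speak of the compounds shown alone.

Measured compounds:
compound 1, `Cc1cc[n+]([O-])cc1Oc1ccccc1`: 30 mg/kg
compound 2, `Cc1cc[n+]([O-])cc1Oc1ccc(Cl)cc1`: 100 mg/kg
compound 3, `Cc1ccc(Oc2c[n+]([O-])ccc2C)cc1`: 300 mg/kg

In a functional assay on the whole organism with Mus musculus as the target, in the maximal electroshock model, with a stated time of 30 min (on this read-out higher numbers stand for an effect only at larger amounts of compound and lower numbers for an effect already at smaller amounts), compound 1 stands at the lowest number of the three. The nearest is compound 2, reached by a 3.3-fold higher number from compound 1 to compound 2 (0.52 log units; beyond the scatter); compound 3 lies furthest, reached by a 10-fold higher number from compound 1 to compound 3 (1.00 log units; beyond the scatter). Between the two substituted analogues the step is a 3.0-fold higher number from compound 2 to compound 3 (0.48 log units; beyond the scatter).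

Compound 4, `CCc1cc[n+]([O-])cc1Oc1ccccc1`, is still to be measured in this assay. It differs from compound 1 by methyl in place of hydrogen on a saturated chain carbon bound to an aromatic carbon. Among the compounds with values here, no measured step touches that place: each of the three steps replaces hydrogen or chloro on an aromatic carbon, so none bears directly on the change to compound 4. What the measured steps do show is that every added group in this small set raised the number, with a 10-fold higher number from compound 1 to compound 3 (1.00 log units; beyond the scatter) the larger of the two additions to compound 1. With the change now sitting on a saturated chain carbon rather than an aromatic carbon, the carry-over is uncertain; a small rise in the number is the cautious expectation, and a step within the scatter is just as plausible.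

Compound 4 is therefore expected to give about 40 mg/kg, with a range of 15 mg/kg to 100 mg/kg. This estimate corresponds to an expected step of a 1.3-fold higher number from compound 1 to compound 4 (0.12 log units; within the scatter).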

Compound 4, minimum effective dose: 30 mg/kg
Estimate against measurement, compound 4: 1.3-fold (0.12 log units) above; the measured number falls inside the stated range.
By their numbers in this assay, from the lowest: compounds 1 and 4 (each within the scatter of the next); then compound 2; then compound 3.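

In this assay, methyl in place of hydrogen on a saturated chain carbon bound to an aromatic carbon, read as methyl to ethyl, gives no change at the digits printed from compound 1 to compound 4 (within the scatter), so this place accepts the extra methyl with no step beyond the scatter. The earlier additions, both on an aromatic carbon, gave a 3.3-fold higher number from compound 1 to compound 2 (0.52 log units; beyond the scatter) and a 10-fold higher number from compound 1 to compound 3 (1.00 log units; beyond the scatter), so compound 4 goes against the earlier picture in which each added group raised the number, and the sensitivity seen at those aromatic carbons does not carry over to this place. No evidence at hand bears on the reason for this result.

As far as these compounds go, a single replacement shows only that ethyl is accommodated here, and how far this holds remains open for a longer chain such as propyl, or for an amine or a carboxylic acid carried on that saturated chain. From the compounds shown here alone, it is also open whether ethyl would read the same when combined with the chloro of compound 2 or the aromatic methyl of compound 3.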